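The source may report more compounds than this note shows. Statements on the series, on what has been measured and on what is new or still open speak of the compounds shown alone.

Working notes on the series. In a functional assay on HCT-116 cells (Homo sapiens) for cytotoxicity, read by MTT assay, with a stated time of 48 h (on this read-out higher numbers stand for weaker inhibition of growth and lower numbers for stronger inhibition of growth), compound 1 `CC(C)n1c(C(F)(F)F)nc2cc(Cl)c(Cl)cc21` gives 81900 nM, compound 2 `Clc1cc2ncn(C3CCCC3)c2cc1Cl` gives 37000 nM and compound 3 `FC(F)(F)c1nc2cc(Cl)c(Cl)cc2n1C1CCCC1` gives 22000 nM. Compound 3 thus has the lowest of the three numbers, but it lies within the scatter of compound 2 and clearly apart only from compound 1.

The next compound is compound 4 `CSc1nc2cc(Cl)c(Cl)cc2n1C1CCCC1`. The change is methylsulfanyl in place of trifluoromethyl on an aromatic carbon, between two ring nitrogen atoms and next to the ring atom that bears a cyclopentyl group.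

Going by the values given here, only one measured step touches this carbon: a 1.7-fold lower number from compound 2 to compound 3 (0.23 log units; within the scatter), with trifluoromethyl in place of hydrogen. The other, a 3.7-fold lower number from compound 1 to compound 3 (0.57 log units; beyond the scatter), is a modest step with cyclopentyl in place of isopropyl on an aromatic nitrogen, so it concerns a different place and stays constant here. Among the compounds with values here, no measured compound carries methylsulfanyl, so the direction remains open. With hydrogen and trifluoromethyl at this carbon differing by no more than the scatter, no step beyond the scatter is expected in this assay. The estimated step is a 1.1-fold higher number from compound 3 to compound 4 (0.06 log units; within the scatter). Compound 4 is estimated at 25000 nM, with an expected range of 10000 nM to 60000 nM.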

Compound 4, concentration for 50% growth inhibition: 2900 nM
Compound 4: middle estimate off by 8.6-fold (0.94 log units), on the high side; measured number outside the range, below it.
By their numbers in this assay, from the lowest: compound 4; then compounds 3 and 2 (each within the scatter of the next); then compound 1.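

In this assay this carbon, between two ring nitrogen atoms, proves sensitive to the group it bears: methylsulfanyl gives a 7.6-fold lower number from compound 3 to compound 4 (0.88 log units; beyond the scatter) and a 13-fold lower number from compound 2 to compound 4 (1.11 log units; beyond the scatter). The earlier pair, hydrogen and trifluoromethyl, stayed within the scatter of each other, so the flat picture at this carbon holds for those two groups only and does not extend to methylsulfanyl, which brings one hydrogen-bond acceptor and has fewer heavy atoms than trifluoromethyl. Nothing available on the compounds accounts for the size of this step, so the result stands as an observation without an explanation.

Still open, on these data alone, is whether the stronger inhibition of growth goes with the sulfur itself or with the whole methylsulfanyl group, a question that methoxy, an amine or a longer chain such as ethylsulfanyl at this carbon would bear on. Going by these compounds alone, also open is whether the step from methylsulfanyl holds with isopropyl in place of cyclopentyl on the aromatic nitrogen, as the only step at that nitrogen was read with trifluoromethyl at this carbon.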